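From furan-3-yl to pyridin-2-yl on a shared core

The source may hold more compounds than are shown below. What is called first, only, known or untested is meant among the compounds shown, and "the series" means these compounds.

Measured so far in an ADME assay on MT4 cells (Homo sapiens) for cytotoxicity, read by MTT assay, with a stated time of 96 h; on this read-out lower numbers stand for higher toxicity in this test and higher numbers for lower toxicity in this test:
compound 1 `CC(=O)c1ccc2c(c1)nc(-c1ccccn1)n2C1CCCCC1` gives 70000 nM
compound 2 `C/C(=N\NC(N)=S)c1ccc2c(c1)nc(-c1ccoc1)n2C1CCCCC1` gives 21000 nM

Of these two, compound 2 has the lower number (21000 nM), and compound 1 (70000 nM) lies above it by more than the usual scatter. The two compounds differ in more than one place, so their gap cannot be assigned to any single change.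

The next compound, compound 3 `C/C(=N\NC(N)=S)c1ccc2c(c1)nc(-c1ccccn1)n2C1CCCCC1`, has not yet been measured in this assay and differs from compound 2 in one place. It carries pyridin-2-yl in place of furan-3-yl on an aromatic carbon of the five-membered aromatic ring with 2 nitrogen, between two ring nitrogen atoms.

Going by the values given here, no measured pair isolates this swap. Among the compounds with values here, the only guide is compound 1, which also carries pyridin-2-yl and gives 70000 nM, so a small upward move at most is expected. The expected change is a 1.2-fold higher number from compound 2 to compound 3 (0.08 log units; within the scatter), which would not go beyond the scatter. The estimated value for compound 3 is 25000 nM, with an expected range (8000 nM to 75000 nM).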

Compound 3, half-maximal cytotoxic concentration: 23000 nM
The estimate for compound 3 lay 1.1-fold (0.04 log units) above the measured number; the measured number falls inside the stated range.
By their numbers in this assay, from the lowest: compounds 2 and 3 (each within the scatter of the next); then compound 1.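

In this assay, putting pyridin-2-yl in place of furan-3-yl on the aromatic carbon between two ring nitrogen atoms, next to the ring atom that bears a cyclohexyl group, amounts to a 1.1-fold higher number from compound 2 to compound 3 (0.04 log units; within the scatter), so at this position the five-membered and the six-membered aromatic ring cannot be told apart in this test. With pyridin-2-yl held fixed, the other place can now be read on its own: the group of 7 heavy atoms in place of the group of 3 heavy atoms gives a 3.0-fold lower number from compound 1 to compound 3 (0.48 log units; beyond the scatter), a modest step, so among these three compounds the read-out moves with that group and not with the ring swap. Nothing available accounts for either step.

Going by these compounds alone, whether this position would read the same with a phenyl ring, a methyl group or an amine remains open, since only two aromatic rings appear there. Going by these compounds, it is also open whether the ring swap would stay as small alongside the group of 3 heavy atoms, or with a cyclopropyl group in place of the cyclohexyl group.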